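The compounds below may be only part of what the source reports. "The series", "measured", "known", "first", "only" and "open" are said of these compounds alone.

Values in an ADME assay (liver) for metabolic stability, with Liver microsome (Rattus norvegicus) as the target, using microsomes and NADPH, with a stated time of 30 min, tested at 1 uM (on this read-out higher numbers stand for fast clearance and lower numbers for slow clearance), for the measured compounds:
compound 1 `COc1cc(C(O)(C(F)(F)F)C(F)(F)F)cnc1N1CCN(S(=O)(=O)c2ccc(N)nc2)CC1` gives < 14 mL.min-1.g-1 (a limit of the assay)
compound 2 `Nc1ccc(S(=O)(=O)N2CCN(c3ncc(C(O)(C(F)(F)F)C(F)(F)F)cc3C3CC3)CC2)cn1` gives 27 mL.min-1.g-1
compound 3 `Nc1ccc(S(=O)(=O)N2CCN(c3ncc(C(O)(C(F)(F)F)C(F)(F)F)cc3C#CCCO)CC2)cn1` gives 68 mL.min-1.g-1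

Compound 3 stands highest of the two true numbers, and the gap to its nearest neighbour is a 2.5-fold higher number from compound 2 to compound 3 (0.40 log units; beyond the scatter) in this series. The entry for compound 1 is a limit and not a number.

Compound 4 `CC(C)n1cc(-c2cc(C(O)(C(F)(F)F)C(F)(F)F)cnc2N2CCN(S(=O)(=O)c3ccc(N)nc3)CC2)cn1` carries 1-isopropyl-1H-pyrazol-4-yl in place of 4-hydroxybut-1-yn-1-yl on an aromatic carbon and is still to be measured. All three measured steps change the group at this same place. Cyclopropyl in place of methoxy gives an at least 1.9-fold higher number from compound 1 to compound 2 (0.28 log units; that floor lies within the scatter) here, and 4-hydroxybut-1-yn-1-yl in place of methoxy gives an at least 4.8-fold higher number from compound 1 to compound 3 (0.68 log units; beyond the scatter) as well. Among the compounds with values here, none of them brings in 1-isopropyl-1H-pyrazol-4-yl, so they fix no direction for the new group, and the only step with two true numbers, a 2.5-fold higher number from compound 2 to compound 3 (0.40 log units; beyond the scatter) for compound 3, is modest. The step expected here is a 1.4-fold lower number from compound 3 to compound 4 (0.13 log units; within the scatter) and thus none beyond the scatter. Compound 4 is estimated at 50 mL.min-1.g-1 with an expected range from 20 mL.min-1.g-1 to 120 mL.min-1.g-1 in this assay overall.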

Compound 4, intrinsic clearance in microsomes: 198 mL.min-1.g-1
The estimate for compound 4 lay 4.0-fold (0.60 log units) below the measured number, outside the stated range (above it).
By their numbers in this assay, from the lowest: compound 2; then compound 3; then compound 4. At a limit, below all of these: compound 1.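

In this assay, within the data shown here, the place ortho to a large group, two atoms from the ring nitrogen, proves to have more range than the earlier compounds showed: 1-isopropyl-1H-pyrazol-4-yl in place of 4-hydroxybut-1-yn-1-yl gives a 2.9-fold higher number from compound 3 to compound 4 (0.46 log units; beyond the scatter), and in place of cyclopropyl it gives a 7.3-fold higher number from compound 2 to compound 4 (0.87 log units; beyond the scatter). Compound 4 now stands highest of the four, with each of its steps beyond the scatter. Against methoxy the change reads as an at least 14-fold higher number from compound 1 to compound 4 (1.15 log units; beyond the scatter), and this is only a floor, for compound 1 stands at a limit and not at a number: the limit of < 14 mL.min-1.g-1 in this assay, at which 1 of the 4 values shown sits.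

The compounds shown do not separate the five-membered aromatic ring from the isopropyl group on it. Going by these compounds, how a pyrazole without that isopropyl group, or an amine at this place, would read in this assay stays open.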